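Trading 4-Fluorophenyl for Cyclopropyl in Compound 3

The source may report more compounds than this note shows. Statements on the series, on what has been measured and on what is new or still open speak of the compounds shown alone.

In a physicochemical assay for solubility, at pH 7.4 (on this read-out lower numbers stand for lower solubility and higher numbers for higher solubility), compound 3 `C[C@H]1[C@H](N)CN1c1c(F)cc2c(=O)c(C(=O)O)cn(-c3ccc(F)cc3)c2c1F` gives 11.2 ug/mL, the highest of the two compounds that have a single number. The nearest is compound 1 `CNC1CN(c2c(F)cc3c(=O)c(C(=O)O)cn(C4CC4)c3c2F)C1` at 1.7 ug/mL, a gap beyond the usual scatter. Compound 2 `CC1(N)CN(c2c(F)cc3c(=O)c(C(=O)O)cn(C4CC4)c3c2F)C1` has no single number, as its two entries read 0.8 ug/mL; 15.3 ug/mL (2 entries) and disagree widely.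

Compound 4 `C[C@H]1[C@H](N)CN1c1c(F)cc2c(=O)c(C(=O)O)cn(C3CC3)c2c1F` has not yet been measured. Compared with compound 3, it has cyclopropyl in place of 4-fluorophenyl on an aromatic nitrogen.

Going by the values given here, no measured pair shows this change alone, so the guide is indirect. Compound 1 at 1.7 ug/mL and compound 2 at 0.8 ug/mL; 15.3 ug/mL (2 entries) also carry cyclopropyl, although both differ from compound 4 elsewhere. Their entries mostly sit lower, but one entry of compound 2 does not, so only a small downward move in this assay seems reasonable. The expected change is a 1.9-fold lower number from compound 3 to compound 4 (0.27 log units; within the scatter), which would stay within the scatter.

The estimate for compound 4 is 6 ug/mL, with an expected range from 1.5 ug/mL to 25 ug/mL.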

Compound 4, solubility: 23.2 ug/mL
Compound 4: middle estimate off by 3.9-fold (0.59 log units), on the low side; low and high end bracket the measured number.
By their numbers in this assay, from the lowest: compound 1; then compound 3; then compound 4.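

Going by these compounds alone, measured directly for the first time, cyclopropyl in place of 4-fluorophenyl on the aromatic nitrogen gives a 2.1-fold higher number from compound 3 to compound 4 (0.32 log units; beyond the scatter) in this assay and so points upward, though this modest step rests on one pair. With cyclopropyl on both compounds, the swap of the group on the aromatic carbon comes with a 14-fold higher number from compound 1 to compound 4 (1.14 log units; beyond the scatter) and is the larger of the two steps. The earlier cyclopropyl compounds could not settle the direction of the change, and compound 2 offers no single number for comparison: the several entries of compound 2 in this assay, 0.8 ug/mL; 15.3 ug/mL (2 entries)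

One pair cannot tell whether the step holds with other groups on the aromatic carbon. Where ethyl or plain phenyl on that aromatic nitrogen would fall in this assay also stays open.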